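A few compounds are considered here, and "the series" means these few. Any claim that something is new, unique, unknown or untested is made for them only; others in the source may bear on it.

Measured in an ADME assay on stomach for pharmacokinetics, in simulated gastric fluid; a higher number here means that the compound lasts longer, a lower number that the compound disappears faster:

- compound 1 `CCOc1cc(NC(=O)C2(NC(=O)c3ccc4c(C5CCCC5)c(-c5ncc(Cl)cn5)n(C)c4c3)CCC2)ccc1/C=C/C(=O)N[C@@H](CCCNC(=N)N)C(N)=O`: 0.467 h
- compound 2 `CCOc1cc(NC(=O)C2(NC(=O)c3ccc4c(C5CCCC5)c(-c5ncc(Cl)cn5)n(C)c4c3)CCC2)ccc1/C=C/C(=O)OCOP(=O)(O)O`: 1.3 h
- compound 3 `CCCCCCOC(=O)/C=C/c1ccc(NC(=O)C2(NC(=O)c3ccc4c(C5CCCC5)c(-c5ncc(Cl)cn5)n(C)c4c3)CCC2)cc1OCC`: 0.883 h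

Compound 3 stands second highest of the three numbers in this assay. Its nearest neighbour is compound 2, and the separation, a 1.5-fold lower number from compound 2 to compound 3 (0.17 log units; within the scatter), lies within the scatter. Its furthest neighbour is compound 1, and that separation, a 1.9-fold higher number from compound 1 to compound 3 (0.28 log units; within the scatter), also lies within the scatter. Among the measured compounds shown here, the one step that clears the scatter is a 2.8-fold higher number from compound 1 to compound 2 (0.44 log units; beyond the scatter), which exchanges the whole group on the carbonyl carbon.

Compound 4 `CCOc1cc(NC(=O)C2(NC(=O)c3ccc4c(C5CCCC5)c(-c5ncc(Cl)cn5)n(C)c4c3)CCC2)ccc1/C=C/C(=O)OCC(N)=O` differs from compound 3 by carbamoyl in place of pentyl on a saturated chain carbon bound to an oxygen next to a carbonyl group. For the measured compounds named here, the only measured step at this same place is a 1.5-fold lower number from compound 2 to compound 3 (0.17 log units; within the scatter), which stayed within the scatter even though it exchanged a group of four oxygen and one phosphorus for five carbon. The other two steps change a different place and give no guide to a chain exchange at the oxygen next to the carbonyl. On this basis the step from compound 3 to compound 4 is expected to be small, a 1.1-fold higher number from compound 3 to compound 4 (0.03 log units; within the scatter), with no clear direction beyond the scatter. Compound 4 is therefore estimated at 0.95 h in this assay, with a range from 0.45 h to 2 h.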

Compound 4, half-life: 0.6 h
Estimate against measurement, compound 4: 1.6-fold (0.20 log units) above; low and high end bracket the measured number.
By their numbers in this assay, from the lowest: compounds 1, 4, 3 and 2 (each within the scatter of the next, the first and the last beyond it).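

At the saturated chain carbon bound to an oxygen next to a carbonyl group, carbamoyl in place of pentyl gives a 1.5-fold lower number from compound 3 to compound 4 (0.17 log units; within the scatter) in this assay, so this exchange of a hydrocarbon chain for a group with a hydrogen-bond donor does not clear the scatter. Among the compounds shown here, the same place is nevertheless not silent: the earlier compounds offered only a step within the scatter here, whereas carbamoyl in place of the phosphorus-bearing group gives a 2.2-fold lower number from compound 2 to compound 4 (0.34 log units; beyond the scatter), the first step beyond the scatter at this position. On the carbonyl carbon, the whole-group exchange gives a 1.3-fold higher number from compound 1 to compound 4 (0.11 log units; within the scatter), so the carbamoylmethoxy group and the arginine-derived amide of compound 1 cannot be told apart in this assay, while the phosphorus-bearing group of compound 2 stands apart from both.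

Open, from the compounds shown here alone, is whether a carboxylic acid or an amine on that chain carbon, or a longer chain ending in carbamoyl, would move the half-life beyond the scatter from compound 3. No measurement at hand accounts for any of these differences.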